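A new ring group on a carbonyl carbon

This account rests on a few compounds, and the source may have more. Where it says the series, first, only, none or still open, it means among the compounds named here.

Compound 1 `O=C(N[C@H]1CN(S(=O)(=O)c2ccccc2)C[C@@H]1C(=O)NC[C@@H]1CCCN1)c1cc(-c2ccccc2Cl)on1` gives 1.5 in a physicochemical assay for lipophilicity, measured as octanol-water partition, at pH 7.4; a lower number here means a more polar compound, a higher number a more lipophilic compound
Compound 2 `CN(C(=O)[C@H]1CN(S(=O)(=O)c2ccccc2)C[C@@H]1NC(=O)c1cc(-c2ccccc2Cl)on1)[C@H]1CCCNC1` gives 1.7 in this assay

In this assay compound 2 stands at 1.7 and cannot be told apart from compound 1 on these numbers. Compound 3 `O=CN1CCC[C@H](NC(=O)[C@H]2CN(S(=O)(=O)c3ccccc3)C[C@@H]2NC(=O)c2cc(-c3ccccc3Cl)on2)C1` departs from compound 2 in one place, and the change is a group of 9 heavy atoms (6 carbon, 2 nitrogen, 1 oxygen; one six-membered non-aromatic ring with 1 hetero atom) in place of a group of 8 heavy atoms (6 carbon, 2 nitrogen; one six-membered non-aromatic ring with 1 hetero atom), on a carbonyl carbon with the entering group holding 1 double bond outside aromatic rings, which the leaving group lacks. Among the measured compounds shown here, only one measured step bears on this, also made on a carbonyl carbon, and it is a number 0.20 log units higher from compound 1 to compound 2 (within the scatter) but it involves a different pair of groups. That step therefore gives only a weak guide to size. For the measured compounds named here, no measured compound carries the entering group, so direction and size remain a matter of judgement, and the range is kept wide. What is expected is a number 0.50 log units higher from compound 2 to compound 3 (beyond the scatter) as a modest step that may exceed the scatter. Compound 3 is estimated at 2.2 with an expected range from 1.6 to 2.8 when it is measured.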

Compound 3, distribution coefficient: 3.1
Estimate against measurement, compound 3: 0.90 log units below, outside the stated range (above it).
By their numbers in this assay, from the lowest: compounds 1 and 2 (each within the scatter of the next); then compound 3.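

The step of a number 1.40 log units higher from compound 2 to compound 3 (beyond the scatter) shows that this assay responds strongly at this carbonyl carbon, a sensitivity that the earlier step, within the scatter, did not reveal. The ring size stays the same across this change, and the counts of hydrogen-bond donors and acceptors and the net charge computed for the two groups also match, so none of these counts separates the groups; what differs is the added oxygen and the double bond outside aromatic rings. The step of a number 1.60 log units higher from compound 1 to compound 3 (beyond the scatter), read as a change on an amide-type nitrogen, is of the same large kind, but no measurement shown here accounts for either rise.

The compounds shown leave open whether the rise belongs to this particular entering group or would also appear with an acetyl group or a urea on the six-membered ring. They also leave open whether the five-membered non-aromatic ring group of compound 1 would respond in the same way to such a change.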